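A few compounds are considered here, and "the series" means these few. Any claim that something is new, unique, unknown or untested is made for them only; others in the source may bear on it.

Of the compounds shown here, three have been measured in a physicochemical assay for solubility, read by HPLC, measured as thermodynamic solubility, with a stated time of 4 h, at pH 6.8; a higher number here means a more soluble compound, a lower number a less soluble compound. Compound 1 `Cc1ccc(Oc2ccc3nc(COc4cccc(C(=O)O)c4)n(C)c3n2)cc1C` gives 16 ug/mL, and compound 2 `Cn1c(COc2cccc(C(=O)O)c2)nc2cnc(Oc3ccc4c(c3)CCC4)cc21` gives 70 ug/mL. Compound 3 `Cn1c(COc2cccc(C(=O)O)c2)nc2ccc(Oc3ccccn3)cc21` gives 62 ug/mL, within the scatter of compound 2 and beyond the scatter above compound 1. Compound 4 `Cc1ccc(Oc2ccc3nc(COc4cccc(C(=O)O)c4)n(C)c3c2)nc1` departs from compound 3 by one change, (methyl in place of hydrogen on an aromatic carbon), methyl in place of hydrogen on an aromatic carbon. Among the measured compounds shown here, no measured pair shows this change alone, so the expectation is tentative. A small fall, not clearly beyond the scatter, is expected, since compound 1, which also carries methyl groups on a different core, gives 16 ug/mL. The expected step is a 1.7-fold lower number from compound 3 to compound 4 (0.24 log units; within the scatter). For compound 4 the estimate is 36 ug/mL, with an expected range from 15 ug/mL to 75 ug/mL.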

Compound 4, solubility: 31 ug/mL
The estimate for compound 4 lay 1.2-fold (0.06 log units) above the measured number; low and high end bracket the measured number.
By their numbers in this assay, from the lowest: compounds 1, 4, 3 and 2 (each within the scatter of the next, the first and the last beyond it).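

In this assay, among the compounds shown here, the change from pyridin-2-yl to 5-methylpyridin-2-yl gives a 2.0-fold lower number from compound 3 to compound 4 (0.30 log units; within the scatter) and so provides the first direct reading of a methyl in place of hydrogen. At this position, two atoms from the ring nitrogen and para to a large group, the added methyl does not move the number beyond the scatter. No measurement at hand offers an explanation for this step.

The compounds shown leave open how a methoxy group, an amine or a longer chain would read at this position. They also leave open whether the same methyl would give a similar step on another core.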